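Stripping bromines from the benzylidene ring of compound 3

The source may hold more compounds than are shown below. What is called first, only, known or untested is meant among the compounds shown, and "the series" means these compounds.

Measured so far in a functional assay on MKN-45 cells (Homo sapiens) for cytotoxicity, read by MTT assay, with a stated time of 72 h; on this read-out higher numbers stand for weaker inhibition and lower numbers for stronger inhibition:
compound 1, `CN(C)CCn1cnnc1-c1cc(Oc2ccc(NC(=O)N/N=C/c3c[nH]c4ccccc34)cc2F)ccn1`, gives 790 nM
compound 2, `CN(C)CCn1cnnc1-c1cc(Oc2ccc(NC(=O)N/N=C/c3ccc(O)c(Br)c3)cc2F)ccn1`, gives 1860 nM
compound 3, `CN(C)CCn1cnnc1-c1cc(Oc2ccc(NC(=O)N/N=C/c3cc(Br)c(O)c(Br)c3)cc2F)ccn1`, gives 4320 nM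

Compound 3 stands highest of the three numbers, with compound 2 nearest and compound 1 furthest. The unmeasured compound 4, `CN(C)CCn1cnnc1-c1cc(Oc2ccc(NC(=O)N/N=C/c3cccc(O)c3)cc2F)ccn1`, differs from compound 3 by 3-hydroxyphenyl in place of 3,5-dibromo-4-hydroxyphenyl on a carbon with a double bond to nitrogen. Within the data shown here, one measured step bears on this: the loss of a single bromo appears as the reverse of a 2.3-fold higher number from compound 2 to compound 3 (0.37 log units; beyond the scatter), a modest change. Among the measured compounds shown here, compound 4 takes away both bromines and also carries its hydroxyl at a different position, a shift for which no measured pair gives guidance; the indole-to-phenyl comparisons a 2.4-fold higher number from compound 1 to compound 2 (0.37 log units; beyond the scatter) and a 5.5-fold higher number from compound 1 to compound 3 (0.74 log units; beyond the scatter) only show that the series has been sliding upward as the benzylidene ring changed. The expected step is therefore downward, a 3.3-fold lower number from compound 3 to compound 4 (0.52 log units; beyond the scatter), with wide uncertainty. For compound 4 in this assay the estimated value is 1300 nM, within a range of 400 nM to 4500 nM.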

Compound 4, half-maximal inhibitory concentration: 1370 nM
Beside the measured number, compound 4's estimate is 1.1-fold (0.02 log units) below it; low and high end bracket the measured number.
By their numbers in this assay, from the lowest: compounds 1, 4 and 2 (each within the scatter of the next, the first and the last beyond it); then compound 3.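

In this assay, removing the bromines at this carbon with a double bond to nitrogen, with 3-hydroxyphenyl replacing 3,5-dibromo-4-hydroxyphenyl, gives a 3.2-fold lower number from compound 3 to compound 4 (0.50 log units; beyond the scatter) and so places a bromine-free ring clearly apart from the dibromo ring. The bromine-free ring cannot be separated from the 3-bromo-4-hydroxyphenyl ring, at a 1.4-fold lower number from compound 2 to compound 4 (0.13 log units; within the scatter), or from the 1H-indol-3-yl group, at a 1.7-fold higher number from compound 1 to compound 4 (0.24 log units; within the scatter), even though those two groups stand apart from each other. No measurement of any property is available to explain these steps.

Compound 4 differs from compound 3 both in having no bromines and in where its hydroxyl sits, and the compounds shown do not separate these two changes. Going by these compounds, how an amine or a carboxylic acid in place of the hydroxyl on this ring would read also remains open.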